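Cyclopropyl in Place of 1-Carboxy-2-methylpropyl on the Amide

The source may report more compounds than this note shows. Statements on the series, on what has been measured and on what is new or still open speak of the compounds shown alone.

Measured compounds:
compound 1, `CNC(=O)CCc1ccncc1-c1ccc2ccccc2c1`: 100%
compound 2, `CC(C)[C@@H](NC(=O)/C=C/c1ccncc1-c1ccc2ccccc2c1)C(=O)O`: 77%

In an assay on a protein complex for inhibition of CDK8/Cyclin C (Homo sapiens), with a stated time of 1 h, tested at 10 uM (a higher number here means more inhibition at the concentration tested (going by the name of the read-out), a lower number less inhibition), compound 1 gives 100%, while compound 2 gives 77%, the lower of the two numbers and beyond the scatter from compound 1. Compound 3, `O=C(/C=C/c1ccncc1-c1ccc2ccccc2c1)NC1CC1`, is not yet measured. It differs from compound 2 in one place: cyclopropyl in place of 1-carboxy-2-methylpropyl on an amide-type nitrogen. Since compound 1, with another group on the amide nitrogen, reaches 100%, an upward step is expected, likely beyond the scatter, of about a number 13 percentage points higher from compound 2 to compound 3 (beyond the scatter). Compound 3 is therefore estimated at 90%, between 72% and 100%.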

Compound 3, a percentage reported as inhibition, at one concentration (the size of the read-out at that concentration, not a potency): 102%
Compound 3: the middle estimate sits 12 percentage points below what was measured; measured number outside the range, above it.
By their numbers in this assay, from the lowest: compound 2; then compounds 1 and 3 (each within the scatter of the next).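

In this assay, the step of a number 25 percentage points higher from compound 2 to compound 3 (beyond the scatter) shows that inhibition on this amide-type nitrogen does not depend on the 1-carboxy-2-methylpropyl group, since cyclopropyl serves at least as well. The step of a number 2 percentage points higher from compound 1 to compound 3 (within the scatter) adds that 2-(cyclopropylcarbamoyl)ethenyl and 2-(methylcarbamoyl)ethyl on the aromatic carbon cannot be told apart here. Going by these compounds alone, whether an amine or a longer chain on that nitrogen would hold this level stays open, and a read-out at one concentration gives no potency for either compound. Nothing available accounts for the rise from the 1-carboxy-2-methylpropyl compound.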